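This account rests on a few compounds, and the source may have more. Where it says the series, first, only, none or still open, it means among the compounds named here.

Measured compounds:
compound 1, `CC1CCN(C2CCN(S(=O)(=O)c3cccc(-c4ccccc4F)c3)CC2)CC1`: 10 nM
compound 2, `Cc1ccc(S(=O)(=O)N2CCC(N3CCC(C)CC3)CC2)cc1C`: 24 nM

In a functional assay on DLD-1 cells (Homo sapiens) for antiproliferative activity, read by CellTiter-Glo, with a stated time of 72 h (a lower number here means a stronger inhibitor, a higher number a weaker inhibitor), compound 2 gives the higher of the two numbers; compound 1 sits lower, and that gap lies beyond the usual scatter. Compound 3, `CC1CCN(C2CCN(S(=O)(=O)c3cc(Cl)cc(Cl)c3)CC2)CC1`, is not yet measured. It differs from compound 2 in one place, (3,5-dichlorophenyl in place of 3,4-dimethylphenyl on a sulfonyl sulfur). For the measured compounds named here, no measured pair shows what such a swap does here, so only a small step is expected, in no clear direction. Compound 3 is expected to give about 20 nM, with a likely range from 6 nM to 65 nM. The step this estimate means, a 1.2-fold lower number from compound 2 to compound 3 (0.08 log units; within the scatter), is expected to stay within the usual scatter.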

Compound 3, half-maximal inhibitory concentration: 3400 nM
For compound 3 the middle estimate is 170-fold (2.23 log units) below the measured one, outside the stated range (above it).
By their numbers in this assay, from the lowest: compound 1; then compound 2; then compound 3.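

In this assay replacing 3,4-dimethylphenyl with 3,5-dichlorophenyl on the sulfonyl sulfur gives a 140-fold higher number from compound 2 to compound 3 (2.15 log units; beyond the scatter) even though both groups have the same heavy-atom count and no hydrogen-bond donors or acceptors. Those counts therefore do not predict the outcome at this position, where a single change can have a very large effect. No evidence here explains the step. The swap changes both the substituent and its ring position, so the compounds shown cannot separate the two. Going by these compounds, whether 3,5-dimethylphenyl or 3,4-dichlorophenyl would behave more like compound 2 or compound 3 remains open.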